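Moving a trifluoromethyl group: estimating compound 3

The source may report more compounds than this note shows. Statements on the series, on what has been measured and on what is new or still open speak of the compounds shown alone.

Measured in an ADME assay on HEK-293T cells (Homo sapiens) for cytotoxicity, read by MTT assay, with a stated time of 3 days; a higher number here means that more compound is tolerated, a lower number that less compound is tolerated:
Compound 1 `CC(C)(C)N(Cc1cccc([N+](=O)[O-])c1)C(=O)COC(=O)c1ccc([N+](=O)[O-])o1`: 78000 nM
Compound 2 `CC(C)(C)N(Cc1ccc(C(F)(F)F)cc1)C(=O)COC(=O)c1ccc([N+](=O)[O-])o1`: 36000 nM

Of these two numbers, compound 2 holds the lower, at 36000 nM. Compound 3 `CC(C)(C)N(Cc1cccc(C(F)(F)F)c1)C(=O)COC(=O)c1ccc([N+](=O)[O-])o1` has the same atoms joined differently: 3-(trifluoromethyl)phenyl in place of 4-(trifluoromethyl)phenyl on a saturated chain carbon bound to an amide-type nitrogen. Going by the values given here, only one measured step bears on this change, a 2.2-fold lower number from compound 1 to compound 2 (0.34 log units; beyond the scatter). That step, from 3-nitrophenyl to 4-(trifluoromethyl)phenyl, replaced the group itself, so it offers only a loose guide and suggests a modest size at most. In this assay, a slight rise is expected, with no step beyond the scatter: a 1.3-fold higher number from compound 2 to compound 3 (0.10 log units; within the scatter). For compound 3 the estimated value is 45000 nM, within an expected range of 22000 nM to 90000 nM.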

Compound 3, half-maximal cytotoxic concentration: 68000 nM
Compound 3: middle estimate off by 1.5-fold (0.18 log units), on the low side, within the range that was stated.
By their numbers in this assay, from the lowest: compounds 2, 3 and 1 (each within the scatter of the next, the first and the last beyond it).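

In this assay, 3-(trifluoromethyl)phenyl in place of 4-(trifluoromethyl)phenyl gives a 1.9-fold higher number from compound 2 to compound 3 (0.28 log units; within the scatter), and trifluoromethyl in place of nitro on an aromatic carbon gives a 1.1-fold lower number from compound 1 to compound 3 (0.06 log units; within the scatter). The earlier step changed the group and its place together, and these two steps split it into single changes, neither of them beyond the scatter on its own. Nothing measured here explains these differences. Still open, on these data alone, is whether an amine or a carboxylic acid on that aromatic ring would move the number beyond the scatter.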